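The source may report more compounds than this note shows. Statements on the series, on what has been measured and on what is new or still open speak of the compounds shown alone.

Measured so far:
- compound 1 `CCCCc1ccc(Nc2ncc3ncn([C@@H]4C[C@@H](O)[C@H](CO)O4)c3n2)cc1`: 4800 nM
- compound 2 `CCCCc1ccc(Nc2nc(O)c3ncn(COCCO)c3n2)cc1`: 38000 nM

In a functional assay on HeLa cells (Homo sapiens) for inhibition, read by thymidine incorporation, with a stated time of 3 h (a lower number here means a stronger inhibitor, a higher number a weaker inhibitor), compound 2 has the higher of the two numbers, at 38000 nM, and its gap to compound 1 lies beyond the scatter. These two compounds differ in more than one place, so the gap cannot be assigned to any single change.

The next compound is compound 3 `CCCCc1ccc(Nc2ncc3ncn(COCCO)c3n2)cc1`, which has not yet been measured in this assay. It departs from compound 2 by one change, hydrogen in place of hydroxy on an aromatic carbon. Among the compounds with values here, no single-change step has been measured, so the expectation rests on thin evidence. Compound 1 also carries hydrogen on that carbon and differs from compound 3 elsewhere. Compound 1 gives 4800 nM. A step towards a lower number, and so a stronger inhibitor, is therefore expected, probably beyond the scatter but not reaching the value of compound 1. The expected move is a 3.2-fold lower number from compound 2 to compound 3 (0.50 log units; beyond the scatter). The estimated value for compound 3 is 12000 nM, with an expected range of 3500 nM to 40000 nM.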

Compound 3, half-maximal inhibitory concentration: 4800 nM
Beside the measured number, compound 3's estimate is 2.5-fold (0.40 log units) above it; the measured number falls inside the stated range.
By their numbers in this assay, from the lowest: compounds 1 and 3 (each within the scatter of the next); then compound 2.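

In this assay, within the data shown here, hydrogen in place of hydroxy on the aromatic carbon gives a 7.9-fold lower number from compound 2 to compound 3 (0.90 log units; beyond the scatter), the first single-change reading at this position, and the hydroxy compound is the weaker of the pair. The substituent on the aromatic nitrogen can now be read on its own as well: with hydrogen on that aromatic carbon, (2-hydroxyethoxy)methyl in place of 4-hydroxy-5-(hydroxymethyl)oxolan-2-yl gives no change at the digits printed from compound 1 to compound 3 (within the scatter), so these two groups are not told apart in this assay. Nothing available explains either reading.

Among these compounds, the series so far holds only hydroxy and hydrogen on that carbon, so it remains open how an amine, a methoxy group or a chlorine atom there would read, and whether the hydroxy step keeps its size with 4-hydroxy-5-(hydroxymethyl)oxolan-2-yl on the aromatic nitrogen. The two nitrogen substituents also leave open whether a simple longer alkyl chain or a carboxylic acid at that nitrogen would stay level with them or move the number.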